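Ester to acid in a cytotoxicity series

This account rests on a few compounds, and the source may have more. Where it says the series, first, only, none or still open, it means among the compounds named here.

Measured so far:
Compound 1, `CCOC(=O)/C=C/c1cc(Br)cc(Br)c1OCc1nc(C)c(C)nc1C`: 1590000 nM
Compound 2, `CCOC(=O)/C=C/c1cc(Br)c(OCc2nc(C)c(C)nc2C)c(Br)c1`: 155000 nM
Compound 3, `Cc1nc(C)c(COc2c(Br)cc(Br)cc2/C=C/C(=O)O)nc1C`: 1970000 nM

All three were tested in a functional assay on ECV-304 cells (Homo sapiens) for cytotoxicity, read by MTT assay, with stated times of 24 h and 12 h; a higher number here means that more compound is needed for the effect, a lower number that less compound is needed. Compound 1 and compound 2 are built from the same atoms joined differently; the difference between their two cores is not broken down here. In this assay compound 2 gives the lowest of the three numbers, and its gap to compound 1 and to compound 3 lies beyond the scatter in both cases.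

Compound 3 differs from compound 1 only by hydrogen in place of ethyl on an oxygen next to a carbonyl group. That change made a step of a 1.2-fold higher number from compound 1 to compound 3 (0.09 log units; within the scatter), which is within the scatter, so the ester and the acid behave alike on the core of compound 1.

Compound 4, `Cc1nc(C)c(COc2c(Br)cc(/C=C/C(=O)O)cc2Br)nc1C`, is the acid belonging to compound 2: it differs from compound 2 by hydrogen in place of ethyl on an oxygen next to a carbonyl group, the same change on the other core. Because the earlier step of a 1.2-fold higher number from compound 1 to compound 3 (0.09 log units; within the scatter) was so small, the step from compound 2 to compound 4 is expected to be a 1.2-fold higher number from compound 2 to compound 4 (0.06 log units; within the scatter), about as small. Compound 4 is therefore estimated at 180000 nM in this assay, likely between 60000 nM and 600000 nM.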

Compound 4, half-maximal effective concentration: 3280000 nM
Compound 4: the middle estimate sits 18-fold (1.26 log units) below what was measured, and the stated range ends below it.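

The change from ethoxycarbonyl to carboxy does not carry over from one core to the other in this assay, and the two steps differ clearly: the same change on two cores in this assay, a 1.2-fold higher number (0.09 log units; within the scatter) from compound 1 to compound 3 and a 21-fold higher number (1.33 log units; beyond the scatter) from compound 2 to compound 4, 17-fold (1.23 log units) apart, beyond the scatter of two such steps. On the core of compound 1 the ester and the acid could not be told apart, whereas on the other core the same change gives a large step (a 21-fold higher number from compound 2 to compound 4 (1.33 log units; beyond the scatter)) , so the size of this step depends on the core that carries it, at least in these two pairs. This does not show why the two cores respond so differently, and two pairs are too few to predict the step on any further core.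

Still open, on these data alone, is whether a methyl group or a longer chain in place of ethyl would follow the core of compound 1 or that of compound 2. An amide in place of the ester raises the same question on both cores.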